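The compounds below may be only part of what the source reports. "The series", "measured", "known", "first", "only" and "open" are said of these compounds alone.

Measured so far:
compound 1 `Cn1ncc(Cl)c1-c1cc(C(=O)N[C@@H]2CN[C@H](CCNS(C)(=O)=O)C[C@H]2c2ccc(F)c(F)c2)oc1Cl` — 1530 nM
compound 2 `Cn1ncc(Cl)c1-c1cc(C(=O)N[C@@H]2CN[C@H](CCN3CCCCC3)C[C@H]2c2ccc(Cl)c(Cl)c2)oc1Cl` — 1660 nM
compound 3 `O=C(N[C@@H]1CNCC[C@H]1c1ccc(Cl)cc1)c1ccc(-c2ncnc3c2CCC3O)s1` — 24100 nM

In a functional assay on OVCAR-8 cells (Homo sapiens) for antiproliferative activity (on this read-out higher numbers stand for weaker inhibition and lower numbers for stronger inhibition), compound 2 gives 1660 nM, the second highest of the three numbers. Compound 1, at 1530 nM, sits within the scatter of compound 2; compound 3, at 24100 nM, lies beyond the scatter at a higher number. Compound 4 `COCC[C@@H]1C[C@@H](c2ccc(Cl)c(Cl)c2)[C@H](NC(=O)c2cc(-c3c(Cl)cnn3C)c(Cl)o2)CN1` is not yet measured. Relative to compound 2 the change is methoxy in place of piperidin-1-yl on a saturated chain carbon, two bonds along the chain from a saturated ring carbon. Among the measured compounds shown here, no measured pair shows this change. Compound 1 carries a different end on the same chain, and in this assay its number and that of compound 2 fall within the scatter of each other. For compound 4 the expected step of a 1.5-fold higher number from compound 2 to compound 4 (0.18 log units; within the scatter) is small, toward a somewhat higher number, and may well stay within the scatter. Compound 4 is estimated at 2500 nM, with a range of 900 nM to 7000 nM.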

Compound 4, half-maximal inhibitory concentration: 1060 nM
Estimate against measurement, compound 4: 2.4-fold (0.37 log units) above; low and high end bracket the measured number.
By their numbers in this assay, from the lowest: compounds 4, 1 and 2 (each within the scatter of the next); then compound 3.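

In this assay, among the compounds shown here, the first matched pair at this chain end gives a 1.6-fold lower number from compound 2 to compound 4 (0.19 log units; within the scatter) and so shows that the read-out holds when piperidin-1-yl, with its ring and 6 heavy atoms, gives way to methoxy, with no ring and 2 heavy atoms. On this pair, the size of the group on this saturated chain carbon does not separate the two compounds. Nothing at hand accounts for this result.

This rests on a single pair. Open, as far as these compounds go, is whether a carboxylic acid, a primary amine or a longer chain in place of methoxy would also stay within the scatter of compound 2.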